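Methylsulfonyl for methoxycarbonyl on compound 3

The source may hold more compounds than are shown below. What is called first, only, known or untested is meant among the compounds shown, and "the series" means these compounds.

Going by the values given here, in an ADME assay on MT4 cells (Homo sapiens) for cytotoxicity (a higher number here means that more compound is tolerated, a lower number that less compound is tolerated), compound 3 `COC(=O)c1ccc(NC(=O)CSc2nc3ccccc3n2S(=O)(=O)c2cc(C)cc(C)c2)c(Cl)c1` gives 145000 nM, the only actual number among the three values shown. Compound 1 `Cc1cc(C)cc(S(=O)(=O)n2c(SCC(=O)Nc3ccccc3Br)nc3ccccc32)c1` stands at a limit of the assay, >= 235000 nM. Compound 2 `Cc1cc(C)cc(S(=O)(=O)n2c(SCC(=O)Nc3ccccc3[N+](=O)[O-])nc3ccccc32)c1` also stands at a limit, >= 26000 nM. Compound 4 `Cc1cc(C)cc(S(=O)(=O)n2c(SCC(=O)Nc3ccc(S(C)(=O)=O)cc3Cl)nc3ccccc32)c1` differs from compound 3 by methylsulfonyl in place of methoxycarbonyl on an aromatic carbon, para to a large group. Among the compounds with values here, no measured step covers this exchange. The nearest is an at least 1.6-fold lower number from compound 1 to compound 3 (0.20 log units; that floor lies within the scatter), which brings in the 2-chloro-4-(methoxycarbonyl)phenyl group, and its floor lies within the scatter. The others, a step that the two limits leave unreadable from compound 1 to compound 2 and a step that the limit leaves unreadable from compound 2 to compound 3, give no size. In this assay the expected change is none beyond the scatter, with an expected 1.1-fold lower number from compound 3 to compound 4 (0.05 log units; within the scatter). Compound 4 is estimated at 130000 nM, with a range from 50000 nM to 280000 nM.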

Compound 4, half-maximal cytotoxic concentration: > 221000 nM
Compound 4 ended at the assay's limit (the forecaster's own chance of this, stated with the estimate: 45%); middle value at least 1.7-fold (0.23 log units) from the limit.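

In this assay, methylsulfonyl para to a large group in place of methoxycarbonyl gives an at least 1.5-fold higher number from compound 3 to compound 4 (0.18 log units; that floor lies within the scatter), so this position accepts the exchange with no lower number, although the floor of that step does not clear the scatter. Compound 4 gives > 221000 nM, which is a limit of the assay. The steps to compound 4 from compound 1 and from compound 2 cannot be read. Open, from the compounds shown here alone, is how far compound 4 lies past its limit. Also open, going by these compounds, is whether a carboxylic acid or an amine at this position would be tolerated in the same way.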